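This account rests on a few compounds, and the source may have more. Where it says the series, first, only, none or still open, it means among the compounds named here.

The measured compounds:
Compound 1 `O=C(N/N=C/c1ccccc1)c1cnccn1`: 100%
Compound 2 `O=C(N/N=C/c1cccc(F)c1)c1cnccn1`: 40%
Compound 3 `CCOc1cccc(/C=N/NC(=O)c2cnccn2)c1`: 69%

These numbers come from an ADME assay on J774 cells (Mus musculus) for cytotoxicity, read by MTT assay, with a stated time of 48 h, tested at 150 ug/mL; a lower number here means a stronger effect, a higher number a weaker effect of the compound at the concentration tested. Among the three, compound 3 stands second highest: compound 2 is nearest to it, lower beyond the scatter, and compound 1 is furthest, higher beyond the scatter. Compound 4 `N#Cc1cccc(/C=N/NC(=O)c2cnccn2)c1` has not yet been measured. It differs from compound 3 in one place (cyano in place of ethoxy on an aromatic carbon).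

Among the compounds with values here, no measured step swaps any group for cyano, so the steps that bear on it are those on the same aromatic carbon. The step of a number 31 percentage points lower from compound 1 to compound 3 (beyond the scatter) shows ethoxy in place of hydrogen lowering the number, and a number 29 percentage points higher from compound 2 to compound 3 (beyond the scatter) shows a modest rise from fluoro to ethoxy, while the larger fall a number 60 percentage points lower from compound 1 to compound 2 (beyond the scatter) came with fluoro. Both measured substituents gave numbers below compound 1, but they differ from each other, so the direction for cyano is uncertain. The step expected for compound 4 is a number 11 percentage points lower from compound 3 to compound 4 (beyond the scatter), small and leaning downward. Compound 4 is therefore estimated to give 58% in this assay, within 30% to 88%.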

Compound 4, a percentage reported as activity, at one concentration (the size of the read-out at that concentration, not a potency): 100%
Estimate against measurement, compound 4: 42 percentage points below; the whole stated range lies below it.
By their numbers in this assay, from the lowest: compound 2; then compound 3; then compounds 1 and 4 (each within the scatter of the next).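

In this assay a substituent on this aromatic carbon does not by itself lower the number: cyano in place of hydrogen gives no change at the digits printed from compound 1 to compound 4 (within the scatter) and so stands level with hydrogen, whereas fluoro and ethoxy both gave lower numbers than hydrogen. The identity of the group therefore matters at this carbon, as shown by a number 31 percentage points higher from compound 3 to compound 4 (beyond the scatter) and by a number 60 percentage points higher from compound 2 to compound 4 (beyond the scatter) as well. No measurement offered here explains why cyano parts from the other two groups.

The compounds shown leave open whether an amine or a carboxylic acid on this carbon would stay level with hydrogen, as cyano does, or lower the number, as fluoro and ethoxy do. They also leave open how a longer chain than ethoxy would read in this assay at this same place.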